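Bromo to chloro on the shared core, step to compound 4

A few compounds are considered here, and "the series" means these few. Any claim that something is new, unique, unknown or untested is made for them only; others in the source may bear on it.

Compound 1 `COc1cc(CCc2ccc(Br)cc2)cc(OC)c1O` carries a bromo group para to a large group on the shared core. In a functional assay on A549 cells (Homo sapiens) for antiproliferative activity, read by MTT assay, with a stated time of 72 h (a lower number here means a stronger inhibitor, a higher number a weaker inhibitor), compound 1 gives only a limit, > 25000 nM, and no number. Two of the three values shown are limits of this kind; the point is recorded as the limit of > 25000 nM in this assay, at which 2 of the 3 values shown sit. Compound 2 `COc1cc(CCc2cccc(F)c2)cc(OC)c1O`, with a fluoro group at a different place, gives a number in this assay: compound 2 reaches 2240 nM. Compound 3 `COc1ccc(CCc2ccc([N+](=O)[O-])cc2)cc1OC`, with a nitro group and a different substitution of the other ring, again gives only a limit in this assay, > 25000 nM. Compound 1 therefore stands among the weaker members on the numbers shown, with no step between measured compounds available to size the move.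

Compound 4 `COc1cc(CCc2ccc(Cl)cc2)cc(OC)c1O` differs from compound 1 by chloro in place of bromo on an aromatic carbon. Going by the values given here, no measured pair covers this exact exchange, so the step in this assay is expected to be small, with no direction beyond the scatter. Compound 4 is expected to give 30000 nM, between 8000 nM and 100000 nM, most likely again reported as a limit. The estimated step that the limit leaves unreadable from compound 1 to compound 4 is expected to lie within the scatter.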

Compound 4, half-maximal inhibitory concentration: 22900 nM
Estimate against measurement, compound 4: 1.3-fold (0.12 log units) above, and the stated range covers the measured number.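

With chloro in place of bromo on an aromatic carbon, para to a large group, this position on the shared core now has a number in this assay: compound 4 gives 22900 nM. Compound 1 gives > 25000 nM, which is a limit of the assay and not a number. The step is an at least 1.0-fold lower number from compound 1 to compound 4 (0.03 log units; that floor lies within the scatter), so only a floor can be read, and that floor does not establish a change between these two halogens at this position: the limit of > 25000 nM in this assay, at which 2 of the 4 values shown sit.

From the compounds shown here alone, the true size of the step remains open, as does whether the series at this position extends to a measurable gain in this assay at all, since a single number and a limit fix no trend. Also open, going by these compounds, is how the same place on the shared core responds to a group of another kind, such as an amine, a carboxylic acid or a longer chain, in place of the chloro of compound 4.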